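Swapping a Cyclic Amine at the End of an Ether Chain

This account rests on a few compounds, and the source may have more. Where it says the series, first, only, none or still open, it means among the compounds named here.

Of the compounds shown here, three built on two closely related cores have been tested in a functional assay on HepG2 cells (Homo sapiens) for antiproliferative activity, read by MTT assay, with a stated time of 48 h; on this read-out higher numbers stand for weaker inhibition and lower numbers for stronger inhibition. Compound 1 `CN1CCN(CCCCOc2c(O)cc3oc(-c4ccccc4)cc(=O)c3c2O)CC1` gives 93700 nM in this assay. Compound 2 `O=c1cc(-c2ccccc2)oc2cc(O)c(OCCCCN3CCCC3)c(O)c12` carries a pyrrolidin-1-yl group on the same core. In this assay compound 2 reaches only > 100000 nM, which is a limit of the assay rather than a number (the limit of > 100000 nM in this assay, at which 1 of the 3 values shown sits). Compound 3 `COc1cc2oc(-c3ccccc3)cc(=O)c2c(O)c1OCCCN1CCCC1` is built on a core whose atoms are the same as those of compound 2 but joined differently; the difference between the two cores is not broken down here. In this assay compound 3 gives 4300 nM, the lowest number among the measured compounds, with compound 1 standing well above it.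

The change from compound 2 to compound 1 is 4-methylpiperazin-1-yl in place of pyrrolidin-1-yl on a saturated chain carbon, four bonds along the chain from an oxygen on an aromatic ring, and it made a step of an at least 1.0-fold lower number from compound 2 to compound 1 (0.02 log units; that floor lies within the scatter). Compound 4 `COc1cc2oc(-c3ccccc3)cc(=O)c2c(O)c1OCCCN1CCN(C)CC1`, not yet measured, arises from compound 3 by 4-methylpiperazin-1-yl in place of pyrrolidin-1-yl on a saturated chain carbon, three bonds along the chain from an oxygen on an aromatic ring. The two changes are the same kind of change, not the same: in compound 1 the new group sits four bonds along the chain from an oxygen on an aromatic ring, in compound 4 three bonds along the chain. The expectation for compound 4 rests on the earlier step of an at least 1.0-fold lower number from compound 2 to compound 1 (0.02 log units; that floor lies within the scatter), which stayed within the usual scatter. For compound 4 a step of about a 1.2-fold higher number from compound 3 to compound 4 (0.07 log units; within the scatter) is therefore expected, and its number in this assay is estimated at 5000 nM, between 1500 nM and 16000 nM.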

Compound 4, half-maximal inhibitory concentration: 15100 nM
Beside the measured number, compound 4's estimate is 3.0-fold (0.48 log units) below it; low and high end bracket the measured number.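

In this assay, putting 4-methylpiperazin-1-yl in place of pyrrolidin-1-yl gives a 3.5-fold higher number from compound 3 to compound 4 (0.55 log units; beyond the scatter), and the change does not carry over from one core to the other at the same size: the same change on two cores in this assay, an at least 1.0-fold lower number (0.02 log units; that floor lies within the scatter) from compound 2 to compound 1 and a 3.5-fold higher number (0.55 log units; beyond the scatter) from compound 3 to compound 4, at least 3.7-fold (0.57 log units) apart, beyond the scatter of two such steps

What this does not show is which difference between the two pairs goes with the gap: they differ in their core and also in where the change sits, four bonds along the chain from an oxygen on an aromatic ring in compound 1 and three bonds along the chain in compound 4, and these two differences cannot be separated here. The earlier step also rests on a limit rather than a number, held by compound 2: the limit of > 100000 nM in this assay, at which 1 of the 4 values shown sits.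

The compounds shown leave open whether the swap would give a similar step if the core of compound 3 carried the longer chain of compound 1, or if the core of compound 1 carried the shorter chain of compound 3. They also leave open how another cyclic amine, such as morpholin-4-yl or piperidin-1-yl, would compare with pyrrolidin-1-yl and 4-methylpiperazin-1-yl on either core.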